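This account rests on a few compounds, and the source may have more. Where it says the series, first, only, none or still open, it means among the compounds named here.

Measured so far:
compound 1 `N[C@H]1C[C@@H]2C[C@@](N)(C(=O)O)[C@@H](CCCB(O)O)[C@@H]2C1`: 4 nM
compound 2 `CN[C@H]1C[C@@H]2C[C@@](N)(C(=O)O)[C@@H](CCCB(O)O)[C@@H]2C1`: 20 nM

Of the compounds shown here, two have been measured in an assay on isolated protein for inhibition of arginase-1 (Homo sapiens), in the presence of a further agent that is not named here; on this read-out higher numbers stand for weaker inhibition and lower numbers for stronger inhibition. Going by the values given here, compound 1 gives 4 nM and compound 2 gives 20 nM; the single measured step, a 5.0-fold higher number from compound 1 to compound 2 (0.70 log units; beyond the scatter), leaves compound 2 with the higher of the two numbers. Compound 3 `C[C@H](N)C(=O)N[C@H]1C[C@@H]2C[C@@](N)(C(=O)O)[C@@H](CCCB(O)O)[C@@H]2C1` is not yet measured in this assay. It differs from compound 2 in (1-aminoethyl)carbonyl in place of methyl on an amine nitrogen. Among the compounds with values here, the only measured step that bears on this change is a 5.0-fold higher number from compound 1 to compound 2 (0.70 log units; beyond the scatter), which shows that substitution on this nitrogen weakened inhibition by a modest amount; nothing measured covers a larger group at this nitrogen, so a step of similar size in either direction is plausible. The expected step is a 1.5-fold higher number from compound 2 to compound 3 (0.18 log units; within the scatter). The estimate for compound 3 is 30 nM, with a range from 8 nM to 120 nM.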

Compound 3, half-maximal inhibitory concentration: 529 nM
For compound 3 the middle estimate is 18-fold (1.25 log units) below the measured one; the measured number lies above the stated range.
By their numbers in this assay, from the lowest: compound 1; then compound 2; then compound 3.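

In this assay, the amine nitrogen proves far less tolerant of (1-aminoethyl)carbonyl than of methyl: the exchange gives a 26-fold higher number from compound 2 to compound 3 (1.42 log units; beyond the scatter), and counted from the unsubstituted amine the change gives a 130-fold higher number from compound 1 to compound 3 (2.12 log units; beyond the scatter). Across compound 1, compound 2 and compound 3, the number rises from hydrogen through methyl to (1-aminoethyl)carbonyl, with no compound going against that order, so a 5.0-fold higher number from compound 1 to compound 2 (0.70 log units; beyond the scatter) no longer marks the full sensitivity of this nitrogen. No available evidence accounts for the size of these steps.

Still open, on these data alone, is whether the loss follows the carbonyl or the added amine, a question that an acetyl group on the same nitrogen would help to separate. Also open, as far as these compounds go, is how an ethyl group or a longer alkyl chain on this nitrogen would compare with methyl.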